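Notes on the step from compound 3 to compound 4

A few compounds are considered here, and "the series" means these few. Any claim that something is new, unique, unknown or untested is made for them only; others in the source may bear on it.

Values in a physicochemical assay for solubility, read by chemiluminescence, measured as kinetic solubility (on this read-out lower numbers stand for lower solubility and higher numbers for higher solubility), for the series
- Compound 1 `Cn1ncc2c(NS(=O)(=O)c3cccc(Cl)c3Cl)cccc21` gives 170000 nM
- Compound 2 `COCCOc1nn(C)c2ncnc(NS(=O)(=O)c3cccc(Cl)c3Cl)c12` gives >= 463000 nM as a limit of the assay
- Compound 3 `COc1nc(NS(=O)(=O)c2cccc(Cl)c2Cl)c2c(OC)nn(C)c2n1` gives 148000 nM

Compound 3 at 148000 nM sits within the scatter of compound 1 at 170000 nM on this read-out. The value of compound 2 is a limit and not a number. Compound 4 `COc1nn(C)c2nc(NC3COC3)nc(NS(=O)(=O)c3cccc(Cl)c3Cl)c12` carries (oxetan-3-yl)amino in place of methoxy on an aromatic carbon between two ring nitrogen atoms. For the measured compounds named here, no measured step covers this change, so the anchor is compound 3 at 148000 nM alone. The expected step of a 1.0-fold higher number from compound 3 to compound 4 (0.01 log units; within the scatter) stays within the scatter in this assay with no direction favoured. The expected value for compound 4 is 150000 nM in a range of 50000 nM to 450000 nM as estimated here.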

Compound 4, solubility: >= 712000 nM
Compound 4: a limit, no number (the forecaster's own chance of this, stated with the estimate: 15%); middle value at least 4.7-fold (0.67 log units) from the limit.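

The change from methoxy to (oxetan-3-yl)amino on an aromatic carbon between two ring nitrogen atoms is the only single-place step shown in the series, and in this assay it reads as an at least 4.8-fold higher number from compound 3 to compound 4 (0.68 log units; beyond the scatter). So this position can move the read-out beyond the scatter. The step has only a lower bound because the value of compound 4 is a limit and not a number: the limit of >= 712000 nM in this assay, at which 1 of the 4 values shown sits.

On these data alone, whether a methylamino group or a morpholine at this position would read the same stays open. So does which part of the (oxetan-3-yl)amino group the step follows.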